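This account rests on a few compounds, and the source may have more. Where it says the series, first, only, none or still open, it means among the compounds named here.

Compound 1 `CC(C)N(C)c1ccc2cc(NC(=O)CCc3ccc(C(F)(F)F)cc3)ccc2n1` gives 2 nM in an assay on isolated protein for displacement of a labelled ligand from melanin-concentrating hormone receptor 1 (Homo sapiens); a lower number here means a stronger inhibitor, a higher number a weaker inhibitor. Among the measured compounds shown here, compound 2 `CC(=O)NC1CCN(c2ccc3cc(NC(=O)CCc4ccc(C(F)(F)F)cc4)ccc3n2)C1` gives 5 nM in this assay, the highest of the two numbers so far; the one recorded step, a 2.5-fold higher number from compound 1 to compound 2 (0.40 log units; beyond the scatter), separates them. Compound 3 `O=C(CCc1ccc(C(F)(F)F)cc1)Nc1ccc2nc(N3CC4CCC3CC4)ccc2c1` carries a group of 8 heavy atoms (7 carbon, 1 nitrogen; 2 six-membered non-aromatic rings with 1 hetero atom each) in place of a group of 9 heavy atoms (6 carbon, 2 nitrogen, 1 oxygen; one five-membered non-aromatic ring with 1 hetero atom), on an aromatic carbon. For the measured compounds named here, only that step bears on this change, as it altered the group on the same aromatic carbon. Because a 2.5-fold higher number from compound 1 to compound 2 (0.40 log units; beyond the scatter) was modest, a modest step back toward the lower number is expected for compound 3, a 1.7-fold lower number from compound 2 to compound 3 (0.22 log units; within the scatter). In this assay compound 3 is estimated at 3 nM, within 1 nM to 12 nM.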

Compound 3, half-maximal inhibitory concentration: 3 nM
Compound 3: middle estimate and measured number agree at the digits printed, and the stated range covers the measured number.
By their numbers in this assay, from the lowest: compounds 1, 3 and 2 (each within the scatter of the next, the first and the last beyond it).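

In this assay, the aromatic carbon next to the ring nitrogen also takes a group of 2 six-membered non-aromatic rings, with 0 hydrogen-bond donors: a 1.7-fold lower number from compound 2 to compound 3 (0.22 log units; within the scatter) and a 1.5-fold higher number from compound 1 to compound 3 (0.18 log units; within the scatter). Both steps lie within the scatter, so the acetamide of the 3-acetamidopyrrolidin-1-yl group is not required for a number at this level. Nothing on hand explains these numbers. Still open, going by these compounds, is how a pyrrolidine bearing a carboxylic acid or a primary amine would read at this carbon.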